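The source may report more compounds than this note shows. Statements on the series, on what has been measured and on what is new or still open speak of the compounds shown alone.

Compound 1, `NCc1ccc(C(=O)Nc2ccncc2F)cc1-c1cccc(NC(=O)c2cc(C(=O)O)ccc2F)c1`, and compound 2, `NCc1ccc(C(=O)Nc2ccncc2F)cc1-c1cccc(NC(=O)c2ccc(C(=O)O)cc2)c1`, share a core and differ only in the acid-bearing ring. In an assay on cells for inhibition of Rho-associated protein kinase 2 (Homo sapiens), read by radiometric assay and 33P incorporation, in the presence of a further agent that is not named here (a higher number here means a weaker inhibitor, a lower number a stronger inhibitor), compound 1 reaches only the limit of the assay, < 1 nM. In this assay, among the measured compounds shown here, compound 2 gives 1 nM, the only actual number in the set. The step of a number no lower from compound 1 to compound 2 (the limit leaves the size open) cannot be sized, since the limit of < 1 nM in this assay, at which 1 of the 2 values shown sits, is a limit rather than a number. Compound 3, `COC(=O)c1ccc(C(=O)Nc2cccc(-c3cc(C(=O)Nc4ccncc4F)ccc3CN)c2)cc1`, carries methyl in place of hydrogen on an oxygen next to a carbonyl group, turning the acid of compound 2 into its methyl ester. For the measured compounds named here, no measured step speaks to this change, and the one step available leaves its size open. Her expectation is therefore drawn from compound 2 alone, which gives 1 nM in this assay, with a modest weakening expected for the ester of a 5.0-fold higher number from compound 2 to compound 3 (0.70 log units; beyond the scatter). She estimates that compound 3 will give 5 nM in this assay, within a range of 1 nM to 30 nM.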

Compound 3, half-maximal inhibitory concentration: < 1 nM
Compound 3 ended at the assay's limit (the forecaster's own chance of this, stated with the estimate: 10%); middle value at least 5.0-fold (0.69 log units) away from the limit.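

Compound 3 stands at a limit of this assay, < 1 nM, which is a limit and not a number. Methyl in place of hydrogen on an oxygen next to a carbonyl group gives a number no higher from compound 2 to compound 3 (the limit leaves the size open). The two earlier compounds both carry a carboxy group, whereas compound 3 shows that 4-(methoxycarbonyl)phenyl in this place, with methyl on the oxygen in place of hydrogen, still gives a value at that limit, so the free acid is not required to reach it. None of the new steps can be sized, because a limit stands at one or both ends of each: the limit of < 1 nM in this assay, at which 2 of the 3 values shown sit.

As far as these compounds go, how far the ester and the acids truly lie apart in this assay remains open. Also open, from the compounds shown here alone, is what an ethyl ester, a primary amide or an amine would give in the same place on the ring.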